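Ring contraction at the azole nitrogen: piperidinyl to pyrrolidinyl

The source may hold more compounds than are shown below. What is called first, only, known or untested is meant among the compounds shown, and "the series" means these compounds.

compound 1 `CN1CCN(c2ccc(Nc3ncc4nc(Nc5ccc(F)cc5)n([C@H]5CCCN(S(=O)(=O)C6CC6)C5)c4n3)cc2)CC1` — 1340 nM
compound 2 `CN1CCN(c2ccc(Nc3ncc4nc(Nc5ccc(F)cc5)n([C@@H]5CCCNC5)c4n3)cc2)CC1` — "not determined" (no result reported)
compound 3 `CN1CCN(c2ccc(Nc3ncc4nc(Nc5ccc(F)cc5)n([C@@H]5CCCN(C(=O)CO)C5)c4n3)cc2)CC1` — "not determined" (no result reported)

In a functional assay on A-431 cells (Homo sapiens) for antiproliferative activity, read by MTT assay, with a stated time of 72 h (a higher number here means a weaker inhibitor, a lower number a stronger inhibitor), compound 1 gives 1340 nM. Within the data shown here, it is the only compound of the series with a number; in this assay compound 2 gives "not determined" (no result reported) and compound 3 gives "not determined" (no result reported), so compound 1 stands alone and cannot be ranked against anything.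

Compound 4 `CN1CCN(c2ccc(Nc3ncc4nc(Nc5ccc(F)cc5)n([C@@H]5CCN(S(=O)(=O)C6CC6)C5)c4n3)cc2)CC1` differs from compound 1 by 1-(cyclopropylsulfonyl)pyrrolidin-3-yl in place of 1-(cyclopropylsulfonyl)piperidin-3-yl on an aromatic nitrogen. The shared core is untouched. Among the measured compounds shown here, no step between measured compounds is available to calibrate this change, and nothing points in one direction or the other. The expected 1.1-fold higher number from compound 1 to compound 4 (0.05 log units; within the scatter) is therefore small and not beyond the scatter. Compound 4 is expected to give 1500 nM with a range from 500 nM to 4500 nM.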

Compound 4, half-maximal inhibitory concentration: > 10000 nM
Compound 4 was reported as a limit; the forecaster's own chance of this, stated with the estimate: 5%; at least 6.6-fold (0.82 log units) between middle value and limit.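

In this assay, among these compounds, this is the first readable step at this position, and it shows that the size of the ring on the aromatic nitrogen matters: 1-(cyclopropylsulfonyl)pyrrolidin-3-yl in place of 1-(cyclopropylsulfonyl)piperidin-3-yl gives an at least 7.4-fold higher number from compound 1 to compound 4 (0.87 log units; beyond the scatter). Compound 4 is reported as a limit, not a number, so the full size of the step is unknown: the limit of > 10000 nM in this assay, at which 1 of the 4 values shown sits.

Steps involving compound 2 and compound 3 cannot be read, as neither has a result. Still open, on these data alone, is how an azepan-3-yl ring, or a methylsulfonyl group in place of cyclopropylsulfonyl, would read here.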